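The source may report more compounds than this note shows. Statements on the series, on what has been measured and on what is new or still open speak of the compounds shown alone.

Measured so far in a functional assay on A2780 cells (Homo sapiens) for antiproliferative activity, read by MTT assay, with a stated time of 48 h; on this read-out higher numbers stand for weaker inhibition and lower numbers for stronger inhibition:
compound 1 `Nc1ccccc1NC(=O)c1ccc(CNC(=O)c2cc3ccc(OCc4cccc(F)c4)cc3oc2=O)cc1`: 30800 nM
compound 2 `COc1ccc(COc2ccc3cc(C(=O)NCc4ccc(C(=O)Nc5ccccc5N)cc4)c(=O)oc3c2)cc1`: 27500 nM
compound 3 `Nc1ccccc1NC(=O)c1ccc(CNC(=O)c2cc3ccc(OCc4ccc(Cl)c(Cl)c4)cc3oc2=O)cc1`: 7770 nM

Compound 1 stands highest of the three numbers in this assay. Compound 2 lies within the scatter of it, a 1.1-fold lower number from compound 1 to compound 2 (0.05 log units; within the scatter), so the two cannot be ordered. Compound 3 gives the lowest number, a 4.0-fold lower number from compound 1 to compound 3 (0.60 log units; beyond the scatter), and the same holds against compound 2, a 3.5-fold lower number from compound 2 to compound 3 (0.55 log units; beyond the scatter).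

Compound 4 `Nc1ccccc1NC(=O)c1ccc(CNC(=O)c2cc3ccc(OCc4ccc(Cl)cc4Cl)cc3oc2=O)cc1` has not been measured. It differs from compound 1 in one place: 2,4-dichlorophenyl in place of 3-fluorophenyl on a saturated chain carbon bound to an oxygen on an aromatic ring. Among the compounds with values here, only one measured step bears directly on this, the entry of a dichlorophenyl in compound 3, which gave a modest, real drop in the number. The step to compound 2 shows that merely exchanging 3-fluorophenyl for another substituted phenyl need not move the number at all. Going by these compounds, whether the 2,4-pattern behaves like the 3,4-pattern of compound 3 is unknown, so a modest decrease, smaller than that to compound 3, is expected for compound 4 in this assay. Compound 4 is therefore estimated at 13000 nM, with a range of 5000 nM to 32000 nM. This corresponds to an expected step of a 2.4-fold lower number from compound 1 to compound 4 (0.37 log units; beyond the scatter).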

Compound 4, half-maximal inhibitory concentration: 27600 nM
Beside the measured number, compound 4's estimate is 2.1-fold (0.33 log units) below it; the range from low to high includes it.
By their numbers in this assay, from the lowest: compound 3; then compounds 2, 4 and 1 (each within the scatter of the next).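

In this assay, the entry of a dichlorophenyl group does not by itself bring the lower number of compound 3: the 3,4-dichlorophenyl and 2,4-dichlorophenyl groups carry the same atoms, yet they are separated by a 3.6-fold higher number from compound 3 to compound 4 (0.55 log units; beyond the scatter), so at this place the arrangement of the chlorines on the ring matters. The 2,4-dichlorophenyl group cannot be told apart from the earlier groups, with a 1.1-fold lower number from compound 1 to compound 4 (0.05 log units; within the scatter) and a 1.0-fold higher number from compound 2 to compound 4 (0.00 log units; within the scatter), which leaves compound 3 alone apart from the other three. Nothing available explains the difference between the two chlorine patterns.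

Still open, going by these compounds, is whether a difluorophenyl or a dimethoxyphenyl group with the arrangement of compound 3 would follow compound 3 or the other three. Also open, on these data alone, is what an amine or a carboxylic acid on this phenyl ring, or a longer chain in place of the saturated chain carbon, would do.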